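The source may hold more compounds than are shown below. What is called first, only, known or untested is meant among the compounds shown, and "the series" means these compounds.

Of the compounds shown here, two from this series have been tested in a functional assay on Huh-7 cells (Homo sapiens) for inhibition, read by sulforhodamine B assay, with a stated time of 72 h (a lower number here means a stronger inhibitor, a higher number a weaker inhibitor), so far. Compound 1 `COc1ccc2cc(C(C)c3nnc4n3N=C(c3ccc(Cl)cc3Cl)CS4)ccc2c1` gives 10700 nM in this assay. Compound 2 `CC(C)Cc1ccc(C(C)c2nnc3n2N=C(c2ccc(OC(F)(F)F)cc2)CS3)cc1` gives 3600 nM in this assay, the lower of the two numbers, so compound 2 is the stronger inhibitor of the pair, and the gap to compound 1 lies beyond the usual scatter of repeated measurements.

Compound 3 `CC(C)Cc1ccc(C(C)c2nnc3n2N=C(c2ccc(Br)cc2)CS3)cc1` has not yet been measured. It is built from compound 2 by a single change: bromo in place of trifluoromethoxy on an aromatic carbon. Going by the values given here, nothing among the measured compounds shows how such an exchange affects the numbers in this assay, so there is no measured step to lean on. The expected step from compound 2 to compound 3 is small, a 1.1-fold higher number from compound 2 to compound 3 (0.05 log units; within the scatter), in no particular direction, and not clearly beyond the scatter.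

On that basis compound 3 is estimated to give about 4000 nM in this assay, with a likely range from 1500 nM to 11000 nM.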

Compound 3, half-maximal inhibitory concentration: 4900 nM
Compound 3: the middle estimate sits 1.2-fold (0.09 log units) below what was measured; low and high end bracket the measured number.
By their numbers in this assay, from the lowest: compounds 2 and 3 (each within the scatter of the next); then compound 1.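

In this assay, putting bromo in place of trifluoromethoxy on an aromatic carbon, para to a large group, gives a 1.4-fold higher number from compound 2 to compound 3 (0.13 log units; within the scatter) and so leaves the two compounds within the usual scatter of each other. Going by these compounds alone, this pair is the only measured one here that differs in a single place, and it gives the first direct reading at this position: a group of 5 heavy atoms with 1 hydrogen-bond acceptor and a single bromine atom with none give numbers that cannot be told apart. Nothing measured here explains why these two groups give such similar numbers.

The compounds shown leave open whether an amine, a carboxylic acid or a longer chain at this same place would keep the number in this assay where it is or move it beyond the scatter. Going by these compounds, compound 1 differs from compound 2 in more than one place, so how much each of those differences contributes in this assay also remains open.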